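The source may report more compounds than this note shows. Statements on the series, on what has been measured and on what is new or still open speak of the compounds shown alone.

Measured compounds:
Compound 1, `NC(=O)c1c(NC(=O)c2ccccc2Cl)sc2c1CCN(Cc1ccc(Cl)cc1)C2`: in a functional assay on HeLa cells (Homo sapiens) for antiproliferative activity, with a stated time of 24 h (on this read-out higher numbers stand for weaker inhibition and lower numbers for stronger inhibition), compound 1 gives > 50000 nM, a limit of the assay.
Compound 2, `NC(=O)c1c(NC(=O)c2ccccc2Cl)sc2c1CCN(C(=S)Nc1c(Cl)cccc1Cl)C2`: in this assay compound 2 gives 26500 nM.
Compound 3, `NC(=O)c1c(NC(=O)c2ccccc2)sc2c1CCN(C(=S)Nc1ccccc1Cl)C2`: in this assay compound 3 gives > 50000 nM, again a limit of the assay.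

Compound 3 therefore stands at the limit, together with compound 1 (the limit of > 50000 nM in this assay, at which 2 of the 3 values shown sit); compound 2 alone returns a number. For the measured compounds named here, the only measured single-point step, an at least 1.8-fold lower number from compound 1 to compound 2 (0.27 log units; that floor lies within the scatter), exchanges the group on the ring amine nitrogen and leaves the benzamido part untouched, so it does not bear on the change now in hand.

Compound 4, `Cc1ccccc1C(=O)Nc1sc2c(c1C(N)=O)CCN(C(=S)Nc1ccccc1Cl)C2`, differs from compound 3 by methyl in place of hydrogen on an aromatic carbon. Going by the values given here, no measured step touches the benzamido ring. Compound 1, whose benzoyl ring likewise carries a substituent, sits at the limit too, though its amine substituent differs. Compound 4 is therefore expected to remain near the limit, with the step that the limit leaves unreadable from compound 3 to compound 4 expected to be none beyond the scatter. The estimate for compound 4 in this assay is 60000 nM, with a range of 20000 nM to 200000 nM, and a report of a limit only is the likelier outcome.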

Compound 4, half-maximal inhibitory concentration: 35300 nM
Beside the measured number, compound 4's estimate is 1.7-fold (0.23 log units) above it; the measured number falls inside the stated range.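

In this assay, methyl in place of hydrogen on an aromatic carbon, ortho to a large group on the benzoyl ring, gives an at least 1.4-fold lower number from compound 3 to compound 4 (0.15 log units; that floor lies within the scatter). Compound 3 gives > 50000 nM, a limit of the assay, so this step is only a floor and the true size of the change cannot be read. Compound 4 returns a number where compound 3 does not, yet any reading of this position remains tied to the limit: the limit of > 50000 nM in this assay, at which 2 of the 4 values shown sit.

The compounds shown leave open how an ethyl, a methoxy or an amine on this same carbon would read. As far as these compounds go, it also remains open whether any change on this ring can give a step beyond the scatter.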